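A Second Fluoro on a Well-Tolerated Compound

The compounds below may be only part of what the source reports. "The series", "measured", "known", "first", "only" and "open" are said of these compounds alone.

- Compound 1 `CC(C)n1ncc2c(C(=O)Nc3c(F)cccc3F)cc(-c3cccs3)nc21`: > 200000 nM (a limit)
- Compound 2 `CC(C)n1ncc2c(C(=O)Nc3ncccn3)cc(-c3cccs3)nc21`: 75000 nM
- Compound 3 `CC(C)n1ncc2c(C(=O)Nc3cccc(F)c3)cc(-c3cccs3)nc21`: > 200000 nM (a limit)

All three compounds were tested in an ADME assay on LLC-MK2 cells (Macaca mulatta) for cytotoxicity, read by spectrophotometry and crystal violet staining, with a stated time of 4 days; a lower number here means that less compound is tolerated, a higher number that more compound is tolerated. Compound 3 gives only a limit, > 200000 nM, and not a number. Compound 1 also gives only a limit, > 200000 nM. Compound 2 alone gives a number, 75000 nM. Most of the series therefore sits at the limit of > 200000 nM in this assay, at which 2 of the 3 values shown sit.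

Compound 4 `CC(C)n1ncc2c(C(=O)Nc3ccc(F)c(F)c3)cc(-c3cccs3)nc21` differs from compound 3 by fluoro in place of hydrogen on an aromatic carbon, which turns 3-fluorophenyl into 3,4-difluorophenyl.

For the measured compounds named here, no measured step makes this exact change. The nearest steps all alter the group on the amide-type nitrogen. With 3-fluorophenyl in place of pyrimidin-2-yl there is an at least 2.6-fold higher number from compound 2 to compound 3 (0.42 log units; beyond the scatter). With pyrimidin-2-yl in place of 2,6-difluorophenyl there is an at least 2.6-fold lower number from compound 1 to compound 2 (0.42 log units; beyond the scatter). Both replace a whole ring, so neither is a direct guide to a single added fluoro. Going by the values given here, the only step between two fluorinated phenyl groups is a step that the two limits leave unreadable from compound 1 to compound 3.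

Compound 4 keeps a fluorinated phenyl group, so no step beyond the scatter is expected in this assay, and the expected step is a number no higher from compound 3 to compound 4 (the limit leaves the size open). The estimated value for compound 4 is 200000 nM, with an expected range of 90000 nM to 400000 nM.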

Compound 4, half-maximal cytotoxic concentration: > 200000 nM
Compound 4 was reported as a limit; the forecaster's own chance of this, stated with the estimate: 65%; the middle value lies on the limit itself.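

The second fluoro, which turns 3-fluorophenyl into 3,4-difluorophenyl, shows that this aromatic carbon, ortho to a fluoro group and para to a large group, can carry a fluoro without the compound leaving the limit of this assay. The 3,4-difluorophenyl group also stands clear of pyrimidin-2-yl, with an at least 2.6-fold higher number from compound 2 to compound 4 (0.42 log units; beyond the scatter), so among the compounds shown, all three fluorinated phenyl groups reach the limit, and only compound 2, with pyrimidin-2-yl, gives a number. The steps from compound 1 and from compound 3 to compound 4 join two limits and cannot be read, and the limit now gathers most of the series: the limit of > 200000 nM in this assay, at which 3 of the 4 values shown sit.

Going by these compounds, how compound 1, compound 3 and compound 4 rank among themselves stays open, since a limit gives no number to compare. Also open, on these data alone, is whether a chloro, a methoxy or an amine on this same aromatic carbon would keep the compound at the limit or bring its number down towards that of compound 2.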